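This account rests on a few compounds, and the source may have more. Where it says the series, first, only, none or still open, it means among the compounds named here.

Compound 1, `O=S(=O)(Nc1ccc(-c2nc3ccccc3o2)cc1)c1cccc(O)c1`, gives 62000 nM.
Compound 2, `O=S(=O)(Nc1ccc(-c2nc3ccccc3o2)cc1)c1cccc(Cl)c1`, gives 54000 nM.

Both numbers come from an assay on cells for inhibition of HSP60/HSP10 (Homo sapiens), with a stated time of 60 min; on this read-out higher numbers stand for weaker inhibition and lower numbers for stronger inhibition. Compound 2 and compound 1 share the same core and differ only in the group on the ring attached to the sulfonyl sulfur; the step of a 1.1-fold lower number from compound 1 to compound 2 (0.06 log units; within the scatter), so the two values are indistinguishable on this read-out, and neither compound can be called the stronger inhibitor.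

Compound 3, `O=S(=O)(Nc1ccc(-c2nc3ccccc3o2)cc1)c1ccccc1F`, has not yet been measured. It differs from compound 2 in one place: 2-fluorophenyl in place of 3-chlorophenyl on a sulfonyl sulfur. Among the measured compounds shown here, no measured step bears directly on this change; the only step available, a 1.1-fold lower number from compound 1 to compound 2 (0.06 log units; within the scatter), concerns a different exchange on the same ring and stayed within the scatter. The data therefore offer no reason to expect a shift in either direction, and the expected step from compound 2 to compound 3 is a 1.0-fold higher number from compound 2 to compound 3 (0.01 log units; within the scatter), none beyond the scatter. Compound 3 is thus estimated at 55000 nM in this assay, with a range from 18000 nM to 170000 nM, a wide band because a single within-scatter step is all that is known.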

Compound 3, half-maximal inhibitory concentration: > 100000 nM
Compound 3: a limit, no number; the forecaster's own chance of this, stated with the estimate: 20%; at least 1.8-fold (0.25 log units) between middle value and limit.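

Compound 3 gives > 100000 nM in this assay, which is a limit of the assay and not a number, so neither step has a known size: the limit of > 100000 nM in this assay, at which 1 of the 3 values shown sits.

Replacing the 3-chlorophenyl on the sulfonyl sulfur with 2-fluorophenyl gives an at least 1.8-fold higher number from compound 2 to compound 3 (0.26 log units; that floor lies within the scatter), and replacing the 3-hydroxyphenyl with the same group gives an at least 1.6-fold higher number from compound 1 to compound 3 (0.20 log units; that floor lies within the scatter). Unlike 3-hydroxyphenyl and 3-chlorophenyl, whose values lie within the scatter of each other, 2-fluorophenyl is the first group here to reach the limit, but both floors also lie within the scatter, so a real loss of inhibition is possible and not established.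

The change from 3-chlorophenyl to 2-fluorophenyl alters both the halogen and the number in the group's name, and these compounds cannot separate the two, since 3-fluorophenyl and 2-chlorophenyl are not among them. Also open, from the compounds shown here alone, is how this read-out would respond to a ring bearing an amine or a carboxylic acid, and whether any group on this ring can bring the value clearly below those of compound 1 and compound 2.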